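Replacing the bromophenyl group of compound 1

This account rests on a few compounds, and the source may have more. Where it says the series, first, only, none or still open, it means among the compounds named here.

Compound 1 `COc1cc(N2C(=O)[C@@H](Oc3ccccc3)[C@H]2c2ccc(Br)cc2)cc(OC)c1OC` gives 48000 nM
Compound 2 `COc1cc(N2C(=O)[C@H](Oc3ccccc3)[C@H]2c2ccc(C#N)cc2)cc(OC)c1OC` gives 168000 nM

Both numbers come from a functional assay on MCF7 cells (Homo sapiens) for antiproliferative activity, read by MTT assay, with stated times of 24 h and 72 h; a higher number here means a weaker inhibitor, a lower number a stronger inhibitor. Compound 1 has the lower number of the two, and the gap up to compound 2 lies beyond the usual scatter. So far, compound 1 is therefore the stronger inhibitor of the pair, although its number is still high.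

Compound 3 `COc1ccc([C@@H]2[C@H](Oc3ccccc3)C(=O)N2c2cc(OC)c(OC)c(OC)c2)cc1[N+](=O)[O-]`, not yet measured, keeps the shared core of compound 1 but carries 4-methoxy-3-nitrophenyl in place of 4-bromophenyl on a saturated ring carbon. Among the compounds with values here, no two measured compounds differ in one place only, so the data give no direct size for such a change. A step towards a lower number, beyond the scatter, is still expected, but only loosely: compound 1 sits at 48000 nM, which leaves much room to fall. The expected change is estimated as a 4.8-fold lower number from compound 1 to compound 3 (0.68 log units; beyond the scatter). For compound 3 the estimated value is 10000 nM, with an expected range from 1000 nM to 60000 nM.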

Compound 3, half-maximal inhibitory concentration: 69000 nM
Estimate against measurement, compound 3: 6.9-fold (0.84 log units) below, outside the stated range (above it).
By their numbers in this assay, from the lowest: compounds 1 and 3 (each within the scatter of the next); then compound 2.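

In this assay, within the data shown here, the single change from 4-bromophenyl to 4-methoxy-3-nitrophenyl on the saturated ring carbon gives a 1.4-fold higher number from compound 1 to compound 3 (0.16 log units; within the scatter). Among these compounds, this is the first comparison here of two compounds that differ in one place only, and it shows no real difference between them. At this position, a larger group carrying hydrogen-bond acceptors, which 4-bromophenyl lacks, leaves the antiproliferative reading effectively unchanged, and no accompanying measurement offers an explanation for this.

Among the compounds shown here, a single step describes only this pair, so it remains open whether other groups at this position, such as a phenyl ring carrying an amine or a carboxylic acid, would also leave the number unchanged. Going by these compounds, it also remains open whether replacing the phenoxy group on the neighbouring ring atom with a shorter group such as methoxy, or with an amine, would bring the number down from the high values seen so far.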